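Extending the amide chain on a shared core

The source may report more compounds than this note shows. Statements on the series, on what has been measured and on what is new or still open speak of the compounds shown alone.

Compound 1 `CNC(=O)c1cc(Oc2ccc(NC(=O)c3cc4cccnc4n(-c4ccccc4)c3=O)cc2)ccn1` stands second highest of the three numbers in a functional assay on HT-29 cells (Homo sapiens) for antiproliferative activity, read by MTT assay, with a stated time of 72 h (on this read-out higher numbers stand for weaker inhibition and lower numbers for stronger inhibition), where compound 1 gives 250 nM. Its nearest neighbour is compound 2 `CNC(=O)c1cc(Oc2ccc(NC(=O)c3cc4cccnc4n(-c4ccc(F)cc4)c3=O)cc2)ccn1`, which gives 160 nM; the step of a 1.6-fold lower number from compound 1 to compound 2 (0.19 log units; within the scatter) lies within the scatter. Compound 3 `CNC(=O)c1cc(Oc2ccc(NC(=O)c3cc4cccnc4n(-c4ccc(C(F)(F)F)cc4Cl)c3=O)cc2)ccn1` gives 3190 nM, and the step of a 13-fold higher number from compound 1 to compound 3 (1.11 log units; beyond the scatter) is large, as is the step of a 20-fold higher number from compound 2 to compound 3 (1.30 log units; beyond the scatter). Compound 4 `CCCNC(=O)c1cc(Oc2ccc(NC(=O)c3cc4cccnc4n(-c4ccccc4)c3=O)cc2)ccn1` differs from compound 1 by ethyl in place of hydrogen on a saturated chain carbon bound to an amide-type nitrogen. For the measured compounds named here, none of the measured steps touches this end of the molecule: all three change the group on the aromatic nitrogen, so none bears directly on the change from methylcarbamoyl to propylcarbamoyl. Going by the values given here, compound 1 is the only anchor, and with no measured step at the amide end, the expected step of a 1.2-fold higher number from compound 1 to compound 4 (0.08 log units; within the scatter) is none beyond the scatter, with no clear direction. Compound 4 is therefore estimated to give 300 nM in this assay, with a range from 120 nM to 800 nM.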

Compound 4, half-maximal inhibitory concentration: 98 nM
For compound 4 the middle estimate is 3.1-fold (0.49 log units) above the measured one; measured number outside the range, below it.
By their numbers in this assay, from the lowest: compounds 4, 2 and 1 (each within the scatter of the next, the first and the last beyond it); then compound 3.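

The change from methylcarbamoyl to propylcarbamoyl in this assay gives a 2.6-fold lower number from compound 1 to compound 4 (0.41 log units; beyond the scatter) and so moves the number down, toward stronger inhibition. For the compounds shown here, the earlier compounds changed only the group on the aromatic nitrogen, so this is the first sign that the amide end also affects the read-out, and that adding ethyl on the saturated chain carbon bound to the amide-type nitrogen does not weaken inhibition here. No available evidence accounts for this modest gain.

On these data alone, whether the trend continues to a butyl chain, or holds for a branched isopropyl group or a chain ending in an amine or a carboxylic acid, remains open. As far as these compounds go, it is also open whether propylcarbamoyl has the same effect when 4-fluorophenyl or 2-chloro-4-(trifluoromethyl)phenyl sits on the aromatic nitrogen.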